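The source may hold more compounds than are shown below. What is called first, only, known or untested is meant among the compounds shown, and "the series" means these compounds.

Compound 1 `O=C1COc2ccc(-c3cnc(Cl)c(NS(=O)(=O)c4ccc(F)cc4)c3)cc2N1c1ccccc1` carries a phenyl group on the amide-type nitrogen of its shared core. Among the compounds with values here, in a functional assay on HeLa cells (Homo sapiens) for antiproliferative activity, read by MTT assay, with a stated time of 72 h (a lower number here means a stronger inhibitor, a higher number a weaker inhibitor), compound 1 gives 10300 nM, which is the only actual number in this set. Compound 2 `O=C1COc2ccc(-c3cnc4ccccc4c3)cc2N1c1ccccc1` stands at > 40000 nM in this assay, a value that is a limit of the measurement rather than a number, as noted in the limit of > 40000 nM in this assay, at which 1 of the 2 values shown sits. Compound 3 `O=C1COc2ccc(-c3cnc(Cl)c(NS(=O)(=O)c4ccc(F)cc4)c3)cc2N1C1CCCCC1` has not yet been measured. It differs from compound 1 in one respect: cyclohexyl in place of phenyl on an amide-type nitrogen in a ring. Within the data shown here, no measured pair in this set tells how that exchange plays out, so the expectation can rest only on the weak activity of compound 1. The step from compound 1 to compound 3 is expected to be a 1.5-fold higher number from compound 1 to compound 3 (0.16 log units; within the scatter), a change not clearly beyond the usual scatter in either direction. For compound 3 the estimate in this assay is 15000 nM, within a range from 4000 nM to 45000 nM.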

Compound 3, half-maximal inhibitory concentration: 14300 nM
For compound 3 the middle estimate is 1.0-fold (0.02 log units) above the measured one; measured number inside the range.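

this assay gives the first measured pair at this position: placing cyclohexyl where phenyl stood on the amide-type nitrogen produces a 1.4-fold higher number from compound 1 to compound 3 (0.14 log units; within the scatter). The two groups therefore cannot be told apart in this assay, even though one ring is aromatic and the other is not. Nothing measured here bears on why the two groups read alike.

The compounds shown leave open how this nitrogen would respond to a group other than a six-membered carbon ring, such as a methyl group, a longer alkyl chain or a chain ending in an amine or a carboxylic acid. They also leave open whether the same exchange would read alike when the rest of the molecule is that of compound 2.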